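From a Butyl Chain to a Ring on the Side Chain

The source may report more compounds than this note shows. Statements on the series, on what has been measured and on what is new or still open speak of the compounds shown alone.

In a functional assay on FaDu cells (Homo sapiens) for cytotoxicity, read by MTT assay, with a stated time of 72 h (a higher number here means that more compound is tolerated, a lower number that less compound is tolerated), compound 1 (`COc1ccc(NC(=O)C(=O)c2cn(CCC(=O)O)c3ccccc23)cn1`) reads > 10000 nM and this is a limit of the assay, not a number. Going by the values given here, compound 2 (`CCCCn1cc(C(=O)C(=O)Nc2ccc(OC)nc2)c2ccccc21`) gives 18 nM as the only actual number so far, which leaves it nothing numerical to be ranked against.

Compound 3 (`COc1ccc(NC(=O)C(=O)c2cn(CC3CCCO3)c3ccccc23)cn1`) differs from compound 2 at one place, with oxolan-2-yl in place of propyl on a saturated chain carbon bound to an aromatic nitrogen. The same difference reads butyl to (oxolan-2-yl)methyl.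

Among the compounds with values here, the one measured step on this side chain is an at least 550-fold lower number from compound 1 to compound 2 (2.74 log units; beyond the scatter) and it is large, with ethyl in place of carboxy. Compound 3 carries no carboxy, so a step of that size is not expected from that comparison. The same comparison does show that changes on this chain can count, so a moderate move to a higher number in this assay is expected, on thin evidence. Estimated in this way, the change is a 3.3-fold higher number from compound 2 to compound 3 (0.52 log units; beyond the scatter) for now. For compound 3 the expected value is 60 nM with an estimated range of 12 nM to 400 nM here.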

Compound 3, concentration lethal to 50% of the cells: 31 nM
For compound 3 the middle estimate is 1.9-fold (0.29 log units) above the measured one; the range from low to high includes it.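

In this assay, the replacement of propyl by oxolan-2-yl gives a 1.7-fold higher number from compound 2 to compound 3 (0.24 log units; within the scatter), so compound 2 and compound 3 cannot be told apart in this assay, even though the new group brings a five-membered non-aromatic ring. A second group without the carboxy now also sits far from compound 1, with an at least 320-fold lower number from compound 1 to compound 3 (2.50 log units; beyond the scatter), so among the three compounds shown, the large gap no longer depends on the butyl chain alone. The value of compound 1 is a limit and not a number, so this step, like the earlier one, has no measured upper end: the limit of > 10000 nM in this assay, at which 1 of the 3 values shown sits.

The compounds shown leave open whether an amine or a longer chain at this place would read like compound 2 and compound 3 or as far away as compound 1. They also do not separate the ring of oxolan-2-yl from its oxygen, a question that a cyclopentyl group, which has the ring without the oxygen, would bear on.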